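The compounds below may be only part of what the source reports. "The series", "measured", "known", "first", "only" and "open" are said of these compounds alone.

Measured so far:
compound 1 `CCCCOc1nc(N)c2[nH]c(=O)n(Cc3ccccc3)c2n1` — 0.1 mg/kg
compound 2 `CCc1nc(N)c2nc(O)n(Cc3ccccc3)c2n1` — 3 mg/kg
compound 3 `Nc1nc(SCc2ccccc2)nc2c1nc(O)n2Cc1ccccc1` — > 1 mg/kg, a limit, not a number

Compound 2 has the highest number of the two readable values in a functional assay on the whole organism for activation, with Mus musculus as the target; a lower number here means that less compound is needed, a higher number that more compound is needed for the effect; compound 1 sits far lower, a gap beyond the scatter. For compound 3 this assay gives only a limit, > 1 mg/kg. Among the measured compounds shown here, the one measured step that starts from compound 2, a step that the limit leaves unreadable from compound 2 to compound 3, stays unreadable because the limit of > 1 mg/kg in this assay, at which 1 of the 3 values shown sits, is all that stands for compound 3.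

Compound 4 `Nc1nc(O)nc2c1nc(O)n2Cc1ccccc1` differs from compound 2 by hydroxy in place of ethyl on an aromatic carbon. For the measured compounds named here, no measured step involves a hydroxy at this carbon, so no step bears directly on it; the step from compound 2 to compound 3 is unreadable, and the pair compound 1 and compound 2 differs in more than one place and gives only the two values shown. With no guide, no step beyond the scatter is expected in this assay, so compound 4 is estimated at 3 mg/kg, with a range of 0.5 mg/kg to 20 mg/kg. The expected step of no change at the digits printed from compound 2 to compound 4 (within the scatter) is therefore put at about zero, with wide uncertainty.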

Compound 4, minimum effective dose: 1 mg/kg
For compound 4 the middle estimate is 3.0-fold (0.48 log units) above the measured one; the measured number falls inside the stated range.
By their numbers in this assay, from the lowest: compound 1; then compound 4; then compound 2.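

In this assay, the aromatic carbon between two ring nitrogen atoms now gives its first readable step, a modest one, with hydroxy in place of ethyl: a 3.0-fold lower number from compound 2 to compound 4 (0.48 log units; beyond the scatter). The number at this carbon therefore responds to the group placed there, with hydroxy, which brings a hydrogen-bond donor and acceptor that ethyl lacks, giving the lower number in this one pair, which sets no pattern. Compound 3 carries only a limit. With hydroxy in place of benzylsulfanyl, the data give a number no higher from compound 3 to compound 4 (the limit leaves the size open). The size of the steps that involve this limit cannot be read: the limit of > 1 mg/kg in this assay, at which 1 of the 4 values shown sits.

A single pair cannot separate the loss of ethyl from the gain of hydroxy. From the compounds shown here alone, whether an amine or a methoxy group at this carbon would track with hydroxy or with ethyl remains open, as does the effect of a propyl chain there.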